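Replacing a Ring Hydroxyl with a Prenyl Ether

The source may hold more compounds than are shown below. What is called first, only, known or untested is meant among the compounds shown, and "the series" means these compounds.

Compound 1 `CC(C)=CCC1Cc2c(O)cc(=O)n(CCCO)c2CC1(C)C` gives 25.6% in a functional assay on PANC-1 cells (Homo sapiens) for inhibition, read by MTT assay, with a stated time of 24 h, tested at 10 uM; on this read-out lower numbers stand for less inhibition and higher numbers for more inhibition at the one concentration tested (going by the name of the read-out).
Compound 2 `CCOc1cc(=O)n(CCCO)c2c1CC(CC=C(C)C)C(C)(C)C2` gives 66.5% in this assay.

Compound 1 stands lowest of the two numbers shown. Compound 3 `CC(C)=CCOc1cc(=O)n(CCCO)c2c1CC(CC=C(C)C)C(C)(C)C2` differs from it by 3-methylbut-2-en-1-yl in place of hydrogen on an oxygen on an aromatic ring. Within the data shown here, the one measured step that bears on this change, a number 40.9 percentage points higher from compound 1 to compound 2 (beyond the scatter), placed ethyl on the oxygen on an aromatic ring and was large. A longer chain on that same oxygen is therefore expected to raise the number as well, by about a number 34.4 percentage points higher from compound 1 to compound 3 (beyond the scatter). Compound 3 is expected to give 60%, somewhere between 30% and 85%.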

Compound 3, a percentage reported as inhibition, at one concentration (the size of the read-out at that concentration, not a potency): 20.7%
The estimate for compound 3 lay 39.3 percentage points above the measured number; measured number below the stated range.
By their numbers in this assay, from the lowest: compounds 3 and 1 (each within the scatter of the next); then compound 2.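

On the oxygen on the aromatic ring, the result in this assay depends on which chain is attached: 3-methylbut-2-en-1-yl in place of hydrogen gives a number 4.9 percentage points lower from compound 1 to compound 3 (within the scatter), so this ether and the free hydroxy cannot be told apart. The gain seen with ethyl therefore does not extend to every chain on this oxygen, as the change of the ethyl ether into the 3-methylbut-2-en-1-yl ether gives a number 45.8 percentage points lower from compound 2 to compound 3 (beyond the scatter). Nothing available explains this difference.

As far as these compounds go, whether methyl or propyl on that oxygen would give a number like that of compound 2 or like that of compound 3 stays open. So does the effect of an amine at the end of the chain.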